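Lengthening the Acetoxy Chain in a Low-Toxicity Series

The compounds below may be only part of what the source reports. "The series", "measured", "known", "first", "only" and "open" are said of these compounds alone.

In an ADME assay on L6 cells (Rattus norvegicus) for cytotoxicity, read by resazurin assay, with a stated time of 70 h (a lower number here means a stronger inhibitor, a higher number a weaker inhibitor), compound 1 (`CC(=O)Oc1ccc2c(c1)C(C)=CC(C)(C)N2Cc1ccccc1`) gives 24000 nM, compound 2 (`CC(=O)Oc1ccc2c(c1)C(C)=CC(C)(C)N2Cc1cccc(C#N)c1`) gives 31000 nM and compound 3 (`CC(=O)Oc1ccc2c(c1)C(C)=CC(C)(C)N2Cc1ccc(Cl)c(Cl)c1`) gives 28000 nM, so compound 1 stands within the scatter of both neighbours. Compound 4 (`CCCCCCCC(=O)Oc1ccc2c(c1)C(C)=CC(C)(C)N2Cc1ccccc1`) differs from compound 1 in one place: hexyl in place of hydrogen on a saturated chain carbon bound to a carbonyl carbon, which turns acetoxy into (heptylcarbonyl)oxy. The measured steps, a 1.3-fold higher number from compound 1 to compound 2 (0.11 log units; within the scatter) and a 1.2-fold higher number from compound 1 to compound 3 (0.07 log units; within the scatter), are both small, but they alter the phenyl group and leave the acetoxy untouched. No measurement therefore tests this change directly, and no shift beyond the scatter is expected in this assay, though with wide uncertainty. The expected result is a 1.2-fold lower number from compound 1 to compound 4 (0.08 log units; within the scatter). For compound 4 the estimate is 20000 nM, with an expected range from 7000 nM to 50000 nM.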

Compound 4, half-maximal inhibitory concentration: 220000 nM
The estimate for compound 4 lay 11-fold (1.04 log units) below the measured number; the measured number lies above the stated range.
By their numbers in this assay, from the lowest: compounds 1, 3 and 2 (each within the scatter of the next); then compound 4.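

Changing the phenyl group left the number within the scatter, but this position is different: hexyl in place of hydrogen on a saturated chain carbon bound to a carbonyl carbon gives a 9.2-fold higher number from compound 1 to compound 4 (0.96 log units; beyond the scatter) in this assay. Within the data shown here, the acetoxy group, left untouched in the earlier compounds, is therefore a place where a change can move this number, and here the longer chain goes with weaker inhibition. Nothing measured here explains the shift.

On these data alone, it remains open whether a propyl chain in the same place would give part of this step, and what an amine or a carboxylic acid in place of hexyl would do. Compound 3 also leaves open whether the same lengthening would give a similar step alongside 3,4-dichlorophenyl.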